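Tert-butyl removal on the phenoxy ring

The source may report more compounds than this note shows. Statements on the series, on what has been measured and on what is new or still open speak of the compounds shown alone.

In a functional assay on JeKo-1 cells (Homo sapiens) for antiproliferative activity (a higher number here means a weaker inhibitor, a lower number a stronger inhibitor), compound 1 `Nc1ncnc2c1c(-c1ccc(Oc3ccccc3)cc1)cn2C[C@H]1CCCN1C(CO)CO` gives 14500 nM, compound 2 `CC(C)(C)c1ccc(COc2ccc(-c3cn([C@H]4CCN(C[C@@H]5CO5)C4)c4ncnc(N)c34)cc2)cc1` gives 5970 nM and compound 3 `CC(C)(C)c1ccc(Oc2ccc(-c3cn([C@H]4CCN(C[C@@H]5CO5)C4)c4ncnc(N)c34)cc2)cc1` gives 14800 nM. Compound 3 holds the highest of the three numbers; compound 1 sits within the scatter of it, while compound 2 lies beyond it, through a 2.5-fold higher number from compound 2 to compound 3 (0.39 log units; beyond the scatter). Compound 4 `Nc1ncnc2c1c(-c1ccc(Oc3ccccc3)cc1)cn2[C@H]1CCN(C[C@@H]2CO2)C1` differs from compound 3 by hydrogen in place of tert-butyl on an aromatic carbon. Among the compounds with values here, no measured step covers this change; the single recorded step concerns the oxygen link, not the tert-butyl group. Compound 1 carries the same plain phenoxy group, differs only in the group on the core, and in this assay stands level with compound 3. Little movement is therefore expected, and the expected step is a 1.1-fold lower number from compound 3 to compound 4 (0.02 log units; within the scatter). Compound 4 is estimated near 14000 nM, with a range of 6000 nM to 32000 nM.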

Compound 4, half-maximal inhibitory concentration: 1480 nM
Compound 4: middle estimate off by 9.5-fold (0.98 log units), on the high side; the whole stated range lies above it.
By their numbers in this assay, from the lowest: compound 4; then compound 2; then compounds 1 and 3 (each within the scatter of the next).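

Tert-butyl at this position is not neutral: in this assay, replacing it with hydrogen gives a 10-fold lower number from compound 3 to compound 4 (1.00 log units; beyond the scatter). With the plain phenoxy group in place, the group on the aromatic nitrogen also matters, with a 9.8-fold lower number from compound 1 to compound 4 (0.99 log units; beyond the scatter). The plain phenoxy group also outperforms the 4-(tert-butyl)benzyl ether, with a 4.0-fold lower number from compound 2 to compound 4 (0.61 log units; beyond the scatter).

On these data alone, whether a methyl group or a chlorine atom at this aromatic carbon would stay near compound 4 or move towards compound 3 remains open. Nothing available explains the size of these steps.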